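Extending the ether chain on the cytotoxicity series

This account rests on a few compounds, and the source may have more. Where it says the series, first, only, none or still open, it means among the compounds named here.

The series shares one core, seen in compound 1 `CC1(Cc2ccccc2)OS(=O)(=O)C=C1OCc1ccccc1`, compound 2 `CCC1(Cc2ccccc2)OS(=O)(=O)C=C1OC` and compound 3 `CCC1(Cc2ccccc2)OS(=O)(=O)C=C1NCc1ccccc1`. In an ADME assay on HEL cells (Homo sapiens) for cytotoxicity, with a stated time of 3 days (on this read-out lower numbers stand for higher toxicity in this test and higher numbers for lower toxicity in this test), compound 1 gives 68000 nM, and compound 3 gives 92000 nM. Among the measured compounds shown here, for compound 2 the read-out is only a limit, > 200000 nM, so its value marks the edge of the assay rather than a number; it is the compound sitting at the limit of > 200000 nM in this assay, at which 1 of the 3 values shown sits, and it is the one from which the step here sets out.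

Compound 4 `CCC1(Cc2ccccc2)OS(=O)(=O)C=C1OCCc1ccccc1` differs from compound 2 by one change: benzyl in place of hydrogen on a saturated chain carbon bound to an oxygen on an unsaturated carbon.

For the measured compounds named here, one measured step bears on this. Replacing the methoxy of compound 2 by benzylamino gave an at least 2.1-fold lower number from compound 2 to compound 3 (0.33 log units; beyond the scatter), so adding an aromatic ring on that side of the core has been linked to a somewhat lower number. Compound 1, which carries a benzyloxy group, also sits well within the measured range at 68000 nM. The author therefore expects a modest drop in this assay for compound 4, estimated as an at least 2.0-fold lower number from compound 2 to compound 4 (0.30 log units; that floor lies within the scatter). Compound 4 is accordingly estimated at 100000 nM, with a range from 40000 nM to 250000 nM.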

Compound 4, half-maximal cytotoxic concentration: 48000 nM
For compound 4 the middle estimate is 2.1-fold (0.32 log units) above the measured one; low and high end bracket the measured number.
By their numbers in this assay, from the lowest: compounds 4, 1 and 3 (each within the scatter of the next). At a limit, above all of these: compound 2.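

Benzyl in place of hydrogen on a saturated chain carbon bound to an oxygen on an unsaturated carbon gives an at least 4.1-fold lower number from compound 2 to compound 4 (0.61 log units; beyond the scatter) in this assay. The earlier step from the same compound exchanged the oxygen for a nitrogen while it added the aromatic ring, whereas compound 4 keeps the oxygen, which shows that a lower number at this position does not require the nitrogen. The size of the step is only a floor, because compound 2 stands at a limit of the assay: the limit of > 200000 nM in this assay, at which 1 of the 4 values shown sits.

The compounds shown do not tell whether a plain longer chain on the same oxygen, such as butyl with no aromatic ring, would lower the number as well, or whether an amine or a carboxylic acid at the end of the chain would change the result. From the compounds shown here alone, the effect of chain length between the oxygen and the ring also stays open, as the benzyloxy group appears only in compound 1, which differs from compound 4 in a second place on the core.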